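Adding two fluorines to the sulfonyl phenyl of compound 3

The source may report more compounds than this note shows. Statements on the series, on what has been measured and on what is new or still open speak of the compounds shown alone.

Measured compounds:
- compound 1, `O=C(NCc1ccc(S(=O)(=O)c2cc(F)cc(F)c2)cc1)c1cc2ccncc2o1`: 9 nM
- compound 2, `O=C(NCc1ccc(S(=O)(=O)N2CCCCC2)cc1)c1cnc2nccn2c1`: 130 nM
- compound 3, `O=C(NCc1ccc(S(=O)(=O)c2ccccc2)cc1)c1cnc2nccn2c1`: 68 nM

In a functional assay on A2780 cells (Homo sapiens) for inhibition, read by sulforhodamine B assay, with a stated time of 72 h (on this read-out lower numbers stand for stronger inhibition and higher numbers for weaker inhibition), compound 3 gives 68 nM, the second highest of the three numbers. Its nearest neighbour is compound 2, whose value of 130 nM lies within the scatter of it, so the two cannot be ordered. The furthest is compound 1, whose value of 9 nM is beyond the scatter; compound 1 differs from compound 3 in two places, however, so that gap cannot be assigned to either change alone.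

Compound 4, `O=C(NCc1ccc(S(=O)(=O)c2cc(F)cc(F)c2)cc1)c1cnc2nccn2c1`, has not been measured. It differs from compound 3 by 3,5-difluorophenyl in place of phenyl on a sulfonyl sulfur.

Among the measured compounds shown here, the one measured step, a 1.9-fold lower number from compound 2 to compound 3 (0.28 log units; within the scatter), concerns a different exchange on the same sulfonyl sulfur and does not bear directly on the present one. For the measured compounds named here, no measured pair isolates the fluorination. Only the values of compound 1 and compound 3 hint that the difluorophenyl partner can sit with a lower number. The step from compound 3 to compound 4 is therefore expected to be a 1.9-fold lower number from compound 3 to compound 4 (0.29 log units; within the scatter), modest and uncertain in size. Compound 4 is estimated at 35 nM, within 12 nM to 100 nM.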

Compound 4, half-maximal inhibitory concentration: 3 nM
The estimate for compound 4 lay 12-fold (1.07 log units) above the measured number; the whole stated range lies above it.
By their numbers in this assay, from the lowest: compound 4; then compound 1; then compounds 3 and 2 (each within the scatter of the next).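

In this assay the exchange at this position proves far from neutral: 3,5-difluorophenyl in place of phenyl on a sulfonyl sulfur gives a 23-fold lower number from compound 3 to compound 4 (1.36 log units; beyond the scatter) and so moves the number well beyond the scatter, which the earlier step on the same sulfur, a 1.9-fold lower number from compound 2 to compound 3 (0.28 log units; within the scatter), did not do. Compound 2 and compound 3 could not be ordered, yet 3,5-difluorophenyl in place of piperidin-1-yl gives a 43-fold lower number from compound 2 to compound 4 (1.64 log units; beyond the scatter), so with the shared core held the partner on the sulfonyl sulfur is shown to matter strongly. With the 3,5-difluorophenyl held instead, the exchange of the group on the carbonyl carbon gives a 3.0-fold lower number from compound 1 to compound 4 (0.48 log units; beyond the scatter), a modest step but one beyond the scatter, so that group has a measurable bearing on the number as well.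

The compounds shown leave open whether a monofluorophenyl, a dichlorophenyl or a methoxyphenyl on the sulfonyl sulfur would give a similar number, and so whether the result depends on fluorine or on the pattern of substitution. No supporting data are given that would explain the size of this step.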